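The source may report more compounds than this note shows. Statements on the series, on what has been measured and on what is new or still open speak of the compounds shown alone.

In an ADME assay on RAW264.7 cells (Mus musculus) for cytotoxicity, read by MTT assay, with a stated time of 24 h (on this read-out lower numbers stand for higher toxicity in this test and higher numbers for lower toxicity in this test), three compounds have been measured so far. Compound 1 `O=c1oc2ccc(F)cc2c(=O)n1-c1ccc(Br)cc1F` gives 7200 nM. Compound 3 `O=c1oc2ccc(I)cc2c(=O)n1-c1ccc(Br)cc1F` carries one change relative to compound 1, (iodo in place of fluoro on an aromatic carbon), and in this assay compound 3 gives 8300 nM; that step is a 1.2-fold higher number from compound 1 to compound 3 (0.06 log units; within the scatter). Compound 2 `O=C(Nc1ccc(Cl)cc1F)c1cc(F)ccc1O` is built on a different core, and the difference between the two cores is not broken down here; in this assay compound 2 gives 7700 nM, a number close to those of compound 1 and compound 3.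

Compound 4 `O=C(Nc1ccc(Cl)cc1F)c1cc(I)ccc1O` has not yet been measured. It differs from compound 2 by iodo in place of fluoro on an aromatic carbon. Among the compounds with values here, this is the same kind of change as the one from compound 1 to compound 3, but not the same: in compound 1 the carbon that carries the change is part of a fused or bridged system of two rings, meta to a fused ring and para to a fused ring, whereas in compound 2 it is on a six-membered aromatic ring of carbon only, meta to a large group and para to a hydroxy group.

Because the earlier step was a 1.2-fold higher number from compound 1 to compound 3 (0.06 log units; within the scatter), a step of similar size is expected for compound 4, a 1.1-fold higher number from compound 2 to compound 4 (0.04 log units; within the scatter). In this assay the number estimated for compound 4 is 8500 nM. Four of five repeat measurements are expected for compound 4 to fall between 4500 nM and 16000 nM.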

Compound 4, half-maximal cytotoxic concentration: 8500 nM
For compound 4 middle estimate and measured number coincide at the digits printed; measured number inside the range.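

In this assay, iodo in place of fluoro on an aromatic carbon can now be read on two different cores, and the new reading is a 1.1-fold higher number from compound 2 to compound 4 (0.04 log units; within the scatter). Set beside the earlier reading on the core of compound 1, the two steps agree: the same change on two cores in this assay, a 1.2-fold higher number (0.06 log units; within the scatter) from compound 1 to compound 3 and a 1.1-fold higher number (0.04 log units; within the scatter) from compound 2 to compound 4, 1.0-fold (0.02 log units) apart, within the scatter of two such steps. This shows that, on these two cores, the swap from fluoro to iodo gives a step that cannot be told apart from the ordinary spread of repeated measurements, even though the carbon carrying it sits in a different setting in each core; it does not show that the swap has a real effect of any particular size or direction, and two small steps that agree say little about how a larger effect would carry from one core to another, or about any core beyond these two.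

The compounds shown hold only fluoro and iodo at this carbon, so it remains open whether an amine, a carboxylic acid or a longer chain there would give a step beyond the scatter. On these data alone, it also remains open whether such a step would then be similar on both cores.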